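Chloro for hydroxy on the anilino ring of a purine

The source may report more compounds than this note shows. Statements on the series, on what has been measured and on what is new or still open speak of the compounds shown alone.

The study centres on a shared core carrying a hexyl chain and a trans-aminocyclohexylamino group, with the variation placed on the anilino substituent. Compound 1 `CCCCCCn1cnc2c(Nc3ccc(O)cc3)nc(N[C@H]3CC[C@H](N)CC3)nc21` is the starting point. In a functional assay on K562 cells (Homo sapiens) for inhibition, read by fluorescence, with a stated time of 72 h (on this read-out higher numbers stand for weaker inhibition of growth and lower numbers for stronger inhibition of growth), compound 1 gives 5400 nM. A second member, compound 2 `CC(C)CCn1cnc2c(NCc3cccc(Cl)c3)nc(N[C@H]3CC[C@H](N)CC3)nc21`, which differs in both the alkyl chain and the aryl part, gives 3100 nM in the same assay. For the measured compounds named here, compound 1 and compound 2 thus lie within the usual scatter of each other, so no order between them can be read from these two numbers, and no single-point step between measured compounds is available.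

The new compound, compound 3 `CCCCCCn1cnc2c(Nc3ccc(Cl)cc3)nc(N[C@H]3CC[C@H](N)CC3)nc21`, arises from compound 1 by one change (chloro in place of hydroxy on an aromatic carbon). Nothing measured here speaks to what chloro in place of hydroxy does on this core, so the step is expected to be small, most likely none beyond the scatter, with a slight lean toward stronger inhibition as the more plausible side. The expected step is a 1.5-fold lower number from compound 1 to compound 3 (0.19 log units; within the scatter). Compound 3 is therefore estimated at 3500 nM, within a range from 900 nM to 14000 nM.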

Compound 3, concentration for 50% growth inhibition: 2100 nM
Compound 3: middle estimate off by 1.7-fold (0.22 log units), on the high side; measured number inside the range.
By their numbers in this assay, from the lowest: compounds 3, 2 and 1 (each within the scatter of the next, the first and the last beyond it).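

On the shared core with its hexyl chain, this place on the aromatic ring, para to a large group, is not indifferent to what it carries. In this assay, for the compounds shown here, the exchange of hydroxy for chloro gives a 2.6-fold lower number from compound 1 to compound 3 (0.41 log units; beyond the scatter) and so supplies the first single-change comparison, a modest step toward stronger inhibition of growth that lies beyond the scatter, which the two earlier numbers alone could not show. The exchange takes away a hydrogen-bond donor and a hydrogen-bond acceptor and brings in neither, but no measurement at hand bears on why the number moves, so the step stands here as an observation without an explanation.

What the compounds shown leave open is whether the step is particular to chloro or would also be seen with another group at this place, such as fluoro, methoxy, an amine or a carboxylic acid. They also leave open whether the same exchange would give a step of similar size with a butyl chain or a longer chain in place of the hexyl chain.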